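A few compounds are considered here, and "the series" means these few. Any claim that something is new, unique, unknown or untested is made for them only; others in the source may bear on it.

In a physicochemical assay for solubility, using the shake flask method, in simulated intestinal fluid, measured as kinetic solubility, with a stated time of 2 h, at 25 degrees C, at pH 6.5 (on this read-out higher numbers stand for higher solubility and lower numbers for lower solubility), compound 1 `Cc1nc(C(=O)O)c(N)c2c1C(=O)N(Cc1ccccc1)C2=O` gives 177000 nM and compound 2 `Cc1nc(C(=O)OC2CC2)c(N)c2c1C(=O)N(Cc1ccccc1)C2=O` gives 202000 nM. These two values lie within the scatter of each other, as a 1.1-fold higher number from compound 1 to compound 2 (0.06 log units; within the scatter) shows. Compound 3 `Cc1noc(-c2nc(C)c3c(c2N)C(=O)N(Cc2ccccc2)C3=O)n1` gives < 5000 nM, which is a limit of the assay and not a number.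

Compound 4 `Cc1nc(-c2nc(C(F)(F)F)no2)c(N)c2c1C(=O)N(Cc1ccccc1)C2=O` carries trifluoromethyl in place of methyl on an aromatic carbon. The 3-methyl-1,2,4-oxadiazol-5-yl group thus becomes 3-(trifluoromethyl)-1,2,4-oxadiazol-5-yl.

Two measured steps involve this group: an at least 35-fold lower number from compound 1 to compound 3 (1.54 log units; beyond the scatter) and an at least 40-fold lower number from compound 2 to compound 3 (1.60 log units; beyond the scatter). Both are large and beyond the scatter, but each brings in the whole group in place of a different one. Neither measures a change made on the group itself, so they offer only indirect guidance. For the measured compounds named here, the data hold no step that swaps this methyl for anything else. The closest guide is therefore compound 3, and no step beyond the scatter is expected in this assay.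

The expected change is a step that the limit leaves unreadable from compound 3 to compound 4. A report of only a limit is the likeliest outcome for compound 4. As a number, compound 4 is estimated at 3000 nM, with an expected range from 1000 nM to 8000 nM.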

Compound 4, solubility: < 5000 nM
Compound 4 ended at the assay's limit; the forecaster's own chance of this, stated with the estimate: 70%; the middle value is on the limit's open side.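

Putting trifluoromethyl in place of methyl on this aromatic carbon, between two ring nitrogen atoms, leaves the compound at the limit of this assay, so the step between compound 3 and compound 4 cannot be read and this change has no measurable size here. What can be read is the distance from the earlier pair: with 3-(trifluoromethyl)-1,2,4-oxadiazol-5-yl in place of carboxy there is an at least 35-fold lower number from compound 1 to compound 4 (1.54 log units; beyond the scatter), and with the same group in place of cyclopropyloxycarbonyl there is an at least 40-fold lower number from compound 2 to compound 4 (1.60 log units; beyond the scatter), so the large gap seen with the methyl version remains once methyl is exchanged. The low end of the read-out now holds both compounds with a substituted 1,2,4-oxadiazol-5-yl group, and nothing finer can be seen there: the limit of < 5000 nM in this assay, at which 2 of the 4 values shown sit.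

Going by these compounds, how far compound 3 and compound 4 each lie past that limit stays open, so they may be close together or far apart. Also open, on these data alone, is how an amine or a carboxylic acid in place of trifluoromethyl at this ring carbon would read, and whether either would give a true number rather than a limit.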